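The source may hold more compounds than are shown below. What is called first, only, known or untested is meant among the compounds shown, and "the series" means these compounds.

Measured so far:
Compound 1 `O=C(O)CCNC(=O)[C@@H]1CCCN1S(=O)(=O)c1cc(Cl)cc(Cl)c1`, which in an assay on RPMI-8866 cells for inhibition of integrin alpha-4/beta-1 (Homo sapiens) (a lower number here means a stronger inhibitor, a higher number a weaker inhibitor), gives 1510 nM.
Compound 2 `CC(C)(C)Oc1ccc([C@@H](CC(=O)O)NC(=O)[C@@H]2CCCN2S(=O)(=O)c2cc(Cl)cc(Cl)c2)cc1`, which in this assay gives 0.53 nM.

Going by the values given here, compound 2 stands at the lowest of the two numbers; the only step among the measured compounds is a 2800-fold lower number from compound 1 to compound 2 (3.45 log units; beyond the scatter), which shows how strongly the aryl group at that chain carbon shapes the result. Compound 3 `CS(=O)(=O)c1ccc([C@@H](CC(=O)O)NC(=O)[C@@H]2CCCN2S(=O)(=O)c2cc(Cl)cc(Cl)c2)cc1` differs from compound 2 by methylsulfonyl in place of tert-butoxy on an aromatic carbon. Among the compounds with values here, no measured step bears on this particular exchange, since the one measured step concerns the presence of the whole aryl group rather than what sits on it. The shared core and the aryl group are kept, so a modest rise in the number is expected rather than a return toward compound 1, with a 5.7-fold higher number from compound 2 to compound 3 (0.75 log units; beyond the scatter) as the expected step. Compound 3 is therefore estimated at 3 nM, in a range from 0.5 nM to 20 nM.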

Compound 3, half-maximal inhibitory concentration: 0.55 nM
Compound 3: middle estimate off by 5.5-fold (0.74 log units), on the high side; the range from low to high includes it.
By their numbers in this assay, from the lowest: compounds 2 and 3 (each within the scatter of the next); then compound 1.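

In this assay, putting methylsulfonyl in place of tert-butoxy on the aromatic carbon gives a 1.0-fold higher number from compound 2 to compound 3 (0.02 log units; within the scatter), so these two groups, which differ in their atoms and in their hydrogen-bond acceptor counts, cannot be told apart at this place. The large step seen earlier with the 4-(tert-butoxy)phenyl group is also found with the 4-(methylsulfonyl)phenyl group, at a 2700-fold lower number from compound 1 to compound 3 (3.44 log units; beyond the scatter), so among the compounds shown it is not tied to tert-butoxy. No measured evidence accounts for this tolerance.

The compounds shown leave open whether the aromatic carbon needs any such group at all, since a plain phenyl with hydrogen there is not among them. They also leave open how an amine or a carboxylic acid on that carbon would compare.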